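The source may report more compounds than this note shows. Statements on the series, on what has been measured and on what is new or still open speak of the compounds shown alone.

The measured compounds and their results in an ADME assay on a cell-free system (plasma, Homo sapiens) for protein binding:

compound 1, `Cc1ccc([C@@H](C)Oc2cc3onc(CCC(=O)O)c3cc2Cl)nc1`: 99.7%
compound 2, `C[C@@H](Oc1cc2onc(CCC(=O)O)c2cc1Cl)c1ccc(Cl)cn1`: 99.8%
compound 3, `CCc1cc2oc(=O)n(CCC(=O)O)c2cc1Cl`: 98.7%

Among these three, compound 3 has the highest unbound fraction. Compound 1 is nearest to it, with a lower unbound fraction, and compound 2 is furthest, with a still lower one; both gaps lie beyond the scatter. Among the measured compounds shown here, compounds 1 and 2 share a core that differs from the core of compound 3, and the only measured single step, a 1.5-fold lower unbound fraction from compound 1 to compound 2 (0.18 log units; within the scatter), exchanges one group for another on that shared core.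

Compound 4, `O=C(O)CCn1c(=O)oc2cc(OCC3CCC3)c(Cl)cc21`, arises from compound 3 by cyclobutylmethoxy in place of ethyl on an aromatic carbon. For the measured compounds named here, no measured step shows an exchange of this kind, and the one step that is known concerns a different core and a different pair of groups, so it gives no direct guide. What the data do show is that compound 3 stands at the free end of the three values, and that the two compounds carrying a larger group at the corresponding place bind more. On that basis a modest move toward more binding is expected, within the range of the compounds already seen. Compound 4 is expected to give 99.3%, between 98.4% and 99.7%. The expected step is a 1.9-fold lower unbound fraction from compound 3 to compound 4 (0.27 log units; within the scatter), an estimate rather than a measured result.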

Compound 4, plasma protein binding: 98.1%
For compound 4 the middle estimate is 2.7-fold (0.43 log units) (unbound fraction) below the measured one; the measured number lies below the stated range.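

In this assay, cyclobutylmethoxy in place of ethyl, on an aromatic carbon ortho to a chloro group, gives a 1.5-fold higher unbound fraction from compound 3 to compound 4 (0.16 log units; within the scatter). Among the compounds shown here, on the core of compound 3, this position therefore accepts a group of 6 heavy atoms with a four-membered ring and a hydrogen-bond acceptor in place of one with 2 heavy atoms and neither feature, with no change in this assay that stands out from the scatter; the earlier compounds could not show this, as their only step lay on another core and exchanged another pair of groups. No measurement available here bears on why the result came out this way.

From the compounds shown here alone, what an amine or a hydroxyl group would do at this same aromatic carbon remains open, so one exchange cannot say whether the position is tolerant in general. Going by these compounds, it is also open whether cyclobutylmethoxy and ethyl would differ as little on the core shared by compound 1 and compound 2, which carries a different group at the corresponding place.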